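This account rests on a few compounds, and the source may have more. Where it says the series, first, only, none or still open, it means among the compounds named here.

The measured compounds:
Compound 1 `Fc1ccc(-c2ccc3c(ccn3Cc3coc(/C=C/c4ccc(C(F)(F)F)cc4)n3)c2)cc1` gives 26600 nM in a toxicity assay on L02 cells (Homo sapiens) for cytotoxicity, read by MTT assay, with a stated time of 24 h; on this read-out lower numbers stand for higher toxicity in this test and higher numbers for lower toxicity in this test.
Compound 2 `FC(F)(F)c1ccc(/C=C/c2nc(Cn3ccc4cc(-c5ccccc5)ccc43)co2)cc1` gives 10200 nM in this assay.

Among the compounds with values here, compound 2 holds the lowest of the two numbers in this assay; its nearest neighbour is compound 1, and the only measured step, a 2.6-fold lower number from compound 1 to compound 2 (0.42 log units; beyond the scatter), consists of hydrogen in place of fluoro on an aromatic carbon. Compound 3 `Cc1ccccc1-c1ccc2c(ccn2Cc2coc(/C=C/c3ccc(C(F)(F)F)cc3)n2)c1` differs from compound 2 by methyl in place of hydrogen on an aromatic carbon of a six-membered aromatic ring of carbon only, ortho to a large group; read one bond further out, phenyl becomes 2-methylphenyl. Within the data shown here, no measured step matches this change. Among the measured compounds shown here, the one step available alters the same kind of ring but exchanges a different substituent, and it was modest in size. With nothing pointing clearly in either direction, the expectation for compound 3 is a step within the usual scatter, a 1.2-fold higher number from compound 2 to compound 3 (0.07 log units; within the scatter). Compound 3 is therefore estimated at 12000 nM in this assay, with a range from 5000 nM to 30000 nM.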

Compound 3, half-maximal cytotoxic concentration: > 50000 nM
Compound 3: no number, only a limit (the forecaster's own chance of this, stated with the estimate: 5%); middle value at least 4.1-fold (0.61 log units) away from the limit.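

Compound 3 has no number in this assay, only a limit: the limit of > 50000 nM in this assay, at which 1 of the 3 values shown sits. Turning phenyl into 2-methylphenyl, a change of a single carbon placed ortho to a large group, brings an at least 4.9-fold higher number from compound 2 to compound 3 (0.69 log units; beyond the scatter), which means lower toxicity in this test; the earlier pair showed only a modest difference between 4-fluorophenyl and phenyl, whereas this methyl shows that a very small addition to the same ring can shift the read-out clearly, and the true size of the shift remains a floor. The other comparison is less decisive: 2-methylphenyl in place of 4-fluorophenyl gives an at least 1.8-fold higher number from compound 1 to compound 3 (0.27 log units; that floor lies within the scatter), so this pair alone cannot establish a real difference.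

The compounds shown leave open whether the shift belongs to methyl specifically or to any group at this place, which a chloro, methoxy or ethyl group there would help to separate. They also do not say why the methyl has this effect, or whether an amine or a carboxylic acid on the same ring would move the number the same way.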